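Chain extension from compound 3 in the whole-animal read-out

This account rests on a few compounds, and the source may have more. Where it says the series, first, only, none or still open, it means among the compounds named here.

Compound 3 `CSCn1c(=N)sc2cc(OC(F)(F)F)ccc21` gives the lowest of the three numbers in a functional assay on the whole organism with Rattus norvegicus as the target (on this read-out lower numbers stand for an effect already at smaller amounts and higher numbers for an effect only at larger amounts of compound), with 3 mg/kg; compound 1 `CCCn1c(=N)sc2cc(OC(F)(F)F)ccc21` gives 4.5 mg/kg, a gap within the scatter, while compound 2 `CCCCn1c(=N)sc2cc(OC(F)(F)F)ccc21` gives 10 mg/kg, a gap beyond it. Compound 4 `CSCCCn1c(=N)sc2cc(OC(F)(F)F)ccc21` differs from compound 3 by 2-(methylsulfanyl)ethyl in place of methylsulfanyl on a saturated chain carbon bound to an aromatic nitrogen. The shared core is unchanged; only the chain bound to the aromatic nitrogen is longer. Going by the values given here, the one measured step that extends such a chain, a 2.2-fold higher number from compound 1 to compound 2 (0.35 log units; beyond the scatter), went to a higher number, whereas a 3.3-fold lower number from compound 2 to compound 3 (0.52 log units; beyond the scatter) and a 1.5-fold lower number from compound 1 to compound 3 (0.18 log units; within the scatter) went the other way when a shorter sulfur-bearing chain replaced a longer alkyl one. A modest rise is therefore expected, a 2.3-fold higher number from compound 3 to compound 4 (0.37 log units; beyond the scatter). Compound 4 is estimated at 7 mg/kg, with a range of 3 mg/kg to 16 mg/kg.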

Compound 4, dose for half-maximal effect: 4.2 mg/kg
Compound 4: middle estimate off by 1.7-fold (0.22 log units), on the high side; low and high end bracket the measured number.
By their numbers in this assay, from the lowest: compounds 3, 4 and 1 (each within the scatter of the next); then compound 2.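

In this assay the step of a 1.4-fold higher number from compound 3 to compound 4 (0.15 log units; within the scatter) shows that 2-(methylsulfanyl)ethyl is tolerated in place of methylsulfanyl on this saturated chain carbon bound to an aromatic nitrogen. Three bonds along the chain from that nitrogen, a 2.4-fold lower number from compound 2 to compound 4 (0.38 log units; beyond the scatter) comes with methylsulfanyl in place of methyl and a 1.1-fold lower number from compound 1 to compound 4 (0.03 log units; within the scatter) with methylsulfanyl in place of hydrogen. Nothing measured gives a reason for these steps.

Going by these compounds, whether an amine, a carboxylic acid or a longer sulfur-bearing chain at this place stays in the same range remains open.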